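Solubility in the series: exchanging the five-membered ring on the chain

The source may report more compounds than this note shows. Statements on the series, on what has been measured and on what is new or still open speak of the compounds shown alone.

Within the data shown here, compound 2 `CC(C)C(/C=C1\SC(=O)NC1=O)c1ccc(-c2ccc3cccc(F)c3c2)[nH]c1=O` is the lower of the two numbers so far in a physicochemical assay for solubility, measured as kinetic solubility, at pH 2; on this read-out higher numbers stand for higher solubility and lower numbers for lower solubility: compound 2 gives 4800 nM, while compound 1 `CC(C)C(CC1C(=O)NC(=O)N1C)c1ccc(-c2ccc3cccc(F)c3c2)[nH]c1=O` gives 26600 nM. Among the measured compounds shown here, the only measured step is a 5.5-fold lower number from compound 1 to compound 2 (0.74 log units; beyond the scatter), in which both the ring and the bond to the chain changed at once.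

Compound 3 `CC(C)C(/C=C1/C(=O)NC(=O)N1C)c1ccc(-c2ccc3cccc(F)c3c2)[nH]c1=O` differs from compound 2 in one place: a group of 9 heavy atoms (5 carbon, 2 nitrogen, 2 oxygen; one five-membered non-aromatic ring with 2 hetero atoms) in place of a group of 8 heavy atoms (4 carbon, 1 nitrogen, 2 oxygen, 1 sulfur; one five-membered non-aromatic ring with 2 hetero atoms), on a saturated chain carbon bound to an aromatic carbon and a saturated chain carbon. This brings back the ring of compound 1 while keeping the double bond of compound 2, so the step from compound 1 to compound 2 bears on it only in part, and its size cannot be split between the ring and the double bond on the numbers shown.

Since the ring of compound 3 is that of compound 1, which gives 26600 nM, the number for compound 3 in this assay is expected to move upward from compound 2, by roughly a 2.5-fold higher number from compound 2 to compound 3 (0.40 log units; beyond the scatter), but probably not all the way back. The estimate for compound 3 is 12000 nM, with a range from 4000 nM to 35000 nM.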

Compound 3, solubility: 8300 nM
Beside the measured number, compound 3's estimate is 1.4-fold (0.16 log units) above it, and the stated range covers the measured number.
By their numbers in this assay, from the lowest: compounds 2 and 3 (each within the scatter of the next); then compound 1.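

In this assay, the ring exchange with the double bond kept, a 1.7-fold higher number from compound 2 to compound 3 (0.24 log units; within the scatter), stays within the scatter, so the ring of compound 2 and the ring of compound 3 are not told apart at this position on a saturated chain carbon bound to an aromatic carbon and a saturated chain carbon. The pair that shares one ring and differs only in the link to it gives the step beyond the scatter, a 3.2-fold lower number from compound 1 to compound 3 (0.51 log units; beyond the scatter), which separates the two changes that were combined in the earlier step: on these three compounds the gap falls on the double bond pair, and compound 2 and compound 3 sit together on the same side of it. Nothing on hand speaks to what lies behind these numbers.

Still open, going by these compounds, is whether the link gives a comparable step with the ring of compound 2, since that ring appears here only with the double bond. Also open, on these data alone, is how this assay reads when the position carries a different kind of group altogether, such as a carboxylic acid or a dimethylamino group in place of the ring, on either form of the chain.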